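Fluoro in Place of Hydrogen: From Compound 1 to Compound 3

The source may report more compounds than this note shows. Statements on the series, on what has been measured and on what is new or still open speak of the compounds shown alone.

Compound 1, `CS(=O)(=O)c1ccc2c(c1)CCN2c1ncnc2c(C3CCN(c4ncccn4)CC3)coc12`, is the starting point. Within the data shown here, in a functional assay on cells for agonist activity at Glucose-dependent insulinotropic receptor (Homo sapiens), read by a luciferase reporter, with a stated time of 4 h (a higher number here means that more compound is needed for the effect, a lower number that less compound is needed), compound 1 gives 512 nM, and this is the only plain number among the two results so far. Compound 2, `CN(c1ccc(S(C)(=O)=O)cc1F)c1ncnc2c(C3CCN(C(=O)OC(C)(C)C)CC3)coc12`, in this assay gives > 1000 nM, which is a limit of the assay rather than a number. Compound 2 thus sits at the limit of > 1000 nM in this assay, at which 1 of the 2 values shown sits. Compound 3, `CS(=O)(=O)c1ccc2c(c1)CCN2c1ncnc2c(C3CCN(c4ncc(F)cn4)CC3)coc12`, has not yet been measured in this assay. It differs from compound 1 by fluoro in place of hydrogen on an aromatic carbon. Among the measured compounds shown here, no measured pair shows the effect of this change, so the step is expected to be small, if any, and to stay within the usual scatter. For compound 3 the expected value in this assay is 400 nM, with a likely range from 150 nM to 1100 nM. This amounts to an estimated step of a 1.3-fold lower number from compound 1 to compound 3 (0.11 log units; within the scatter).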

Compound 3, half-maximal effective concentration: 201 nM
The estimate for compound 3 lay 2.0-fold (0.30 log units) above the measured number; measured number inside the range.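

Putting fluoro in place of hydrogen, which turns pyrimidin-2-yl into 5-fluoropyrimidin-2-yl, gives a 2.5-fold lower number from compound 1 to compound 3 (0.41 log units; beyond the scatter) in this assay. Among these compounds, this is the first measured pair that isolates this position, and it shows that a single fluorine atom on this ring, para to a large group, is accepted and that less compound is then needed for the effect, by a modest margin that lies beyond the usual scatter. The values shown offer no measurement that explains this step.

From the compounds shown here alone, a single pair speaks for a single change, so it remains open whether a chlorine atom, a methoxy group or an amine at the same carbon would shift the number in the same direction. Going by these compounds, it also remains open whether fluoro here would give a similar step with other groups elsewhere on the molecule.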